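The source may hold more compounds than are shown below. What is called first, only, known or untested is meant among the compounds shown, and "the series" means these compounds.

Among the compounds with values here, in a functional assay on MIA PaCa-2 cells (Homo sapiens) for inhibition, read by MTT assay, with a stated time of 72 h (on this read-out lower numbers stand for stronger inhibition and higher numbers for weaker inhibition), three compounds have numbers so far: compound 1 (`COc1cc(NC(C)CCCNC(=O)Nc2cccc(Cl)c2)c2ncccc2c1`) gives 21000 nM, compound 2 (`COc1cc(NC(C)CCCNC(=O)NNC(=O)Nc2ccc(Br)cc2)c2ncccc2c1`) gives 231000 nM, and compound 3 (`COc1cc(NC(C)CCCNC(=O)NNC(=O)Nc2cccc(F)c2)c2ncccc2c1`) gives 69000 nM. Compound 3 therefore takes the middle place of the three. Compound 4 (`COc1cc(NC(C)CCCNC(=O)Nc2ccc(O)cc2)c2ncccc2c1`) is still unmeasured. Its difference from compound 3 is 4-hydroxyphenyl in place of ((3-fluorophenyl)carbamoyl)amino on an amide-type nitrogen, with 4-hydroxyphenyl in place of ((3-fluorophenyl)carbamoyl)amino on an amide-type nitrogen. This leaves an aryl group on that nitrogen, as in compound 1 with its 3-chlorophenyl.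

The closest evidence is a 3.3-fold higher number from compound 1 to compound 3 (0.52 log units; beyond the scatter), and an 11-fold higher number from compound 1 to compound 2 (1.04 log units; beyond the scatter) runs the same way. The aryl change alone also counts, as shown by a 3.3-fold lower number from compound 2 to compound 3 (0.52 log units; beyond the scatter). Read in reverse, the first of these steps points to a modest move towards a lower number in this assay. Within the data shown here, no compound with 4-hydroxyphenyl has a measured number, so the range stays wide. The expected size is a 2.5-fold lower number from compound 3 to compound 4 (0.39 log units; beyond the scatter). The estimated value for compound 4 is 28000 nM. The expected range for compound 4 runs from 9000 nM to 85000 nM.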

Compound 4, half-maximal inhibitory concentration: 57000 nM
For compound 4 the middle estimate is 2.0-fold (0.31 log units) below the measured one, and the stated range covers the measured number.
By their numbers in this assay, from the lowest: compound 1; then compounds 4 and 3 (each within the scatter of the next); then compound 2.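

In this assay the 4-hydroxyphenyl group on the amide-type nitrogen does not separate from ((3-fluorophenyl)carbamoyl)amino (a 1.2-fold lower number from compound 3 to compound 4 (0.08 log units; within the scatter)), but it does separate from ((4-bromophenyl)carbamoyl)amino (a 4.1-fold lower number from compound 2 to compound 4 (0.61 log units; beyond the scatter)). An aryl group directly on that nitrogen does not by itself match compound 1, since 4-hydroxyphenyl and 3-chlorophenyl remain apart (a 2.7-fold higher number from compound 1 to compound 4 (0.43 log units; beyond the scatter)), so the choice of aryl group counts at this position as well. No measurement on these groups speaks to the origin of these steps.

From the compounds shown here alone, it remains open whether an amine or a carboxylic acid in place of the hydroxy group of compound 4 would stand nearer to compound 1 or to compound 2. The gap between 3-chlorophenyl and 4-hydroxyphenyl also cannot be assigned to the substituent or to its place on the ring, as the two groups differ in both.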